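Chloro in Place of Hydrogen on a Weakly Active Scaffold

This account rests on a few compounds, and the source may have more. Where it says the series, first, only, none or still open, it means among the compounds named here.

Measured compounds:
compound 1 `COc1ccc(-c2noc(-c3ccccc3)n2)cc1OC1CCCC1` — > 1000000 nM
compound 2 `COc1ccc(-c2noc(C3CCCN3)n2)cc1OC1CCCC1` — 212000 nM
compound 3 `COc1ccc(-c2noc(-c3ccc(O)cc3)n2)cc1OC1CCCC1` — 310 nM

In a functional assay on MDA-MB-231 cells (Homo sapiens) for antiproliferative activity, read by MTT assay, with a stated time of 24 h (on this read-out lower numbers stand for stronger inhibition and higher numbers for weaker inhibition), compound 1 gives > 1000000 nM, which is a limit of the assay and not a number (the limit of > 1000000 nM in this assay, at which 1 of the 3 values shown sits). Compound 2 gives 212000 nM and compound 3 gives 310 nM. Two steps lead away from compound 1: an at least 4.7-fold lower number from compound 1 to compound 2 (0.67 log units; beyond the scatter), and an at least 3200-fold lower number from compound 1 to compound 3 (3.50 log units; beyond the scatter). Between the other two, a 680-fold lower number from compound 2 to compound 3 (2.83 log units; beyond the scatter).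

Compound 4 `COc1ccc(-c2noc(-c3ccc(Cl)cc3)n2)cc1OC1CCCC1` differs from compound 1 in one place: chloro in place of hydrogen on an aromatic carbon. Among the compounds with values here, of the measured steps only the one from compound 1 to compound 3 touches the same phenyl, where hydroxy entered in place of hydrogen; there is no measured example of chloro at that position, and chloro brings no hydrogen-bond donor or acceptor. The account therefore expects a step in this assay that is downward but clearly smaller than the hydroxy step, with wide uncertainty because compound 1 shows only > 1000000 nM. For compound 4 the expected step is an at least 16-fold lower number from compound 1 to compound 4 (1.22 log units; beyond the scatter). Compound 4 is estimated at 60000 nM, within a range of 3000 nM to 1000000 nM.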

Compound 4, half-maximal inhibitory concentration: 396000 nM
The estimate for compound 4 lay 6.6-fold (0.82 log units) below the measured number; low and high end bracket the measured number.
By their numbers in this assay, from the lowest: compound 3; then compounds 2 and 4 (each within the scatter of the next). At a limit, above all of these: compound 1.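

In this assay, chloro in place of hydrogen, para to a large group, gives an at least 2.5-fold lower number from compound 1 to compound 4 (0.40 log units; beyond the scatter), so this position also responds to a group other than hydroxy, though the size of that response cannot be fixed. Compound 1 stands at a limit of the assay and not at a number: the limit of > 1000000 nM in this assay, at which 1 of the 4 values shown sits. The new result also shows how much depends on the group that enters, since chloro in place of hydroxy gives a 1300-fold higher number from compound 3 to compound 4 (3.11 log units; beyond the scatter), while the change from pyrrolidin-2-yl to 4-chlorophenyl gives a 1.9-fold higher number from compound 2 to compound 4 (0.27 log units; within the scatter).

Going by these compounds, it remains open whether an amino group or a carboxylic acid at this position would come close to hydroxy or stay close to chloro. Also open, on these data alone, is whether fluoro or bromo would behave as chloro does here.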